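Removing the Bromo Group from Compound 2

This account rests on a few compounds, and the source may have more. Where it says the series, first, only, none or still open, it means among the compounds named here.

Of the compounds shown here, two built on one shared core have been measured so far. Compound 1 `O=C1N[C@@H](c2c[nH]c3ccccc23)CN=C1c1c[nH]c2ccccc12` and compound 2 `O=C1NC[C@@H](c2c[nH]c3cc(Br)ccc23)N=C1c1c[nH]c2ccccc12` were both examined in an ADME assay on XF498 cells (Homo sapiens) for cytotoxicity; a lower number here means that less compound is needed, a higher number that more compound is needed for the effect. In this assay compound 1 gives 17.1 ug/mL, and compound 2 gives 8.3 ug/mL. Compound 2 therefore holds the lowest number of the two, and the nearest value, that of compound 1, stands higher by a margin beyond the usual scatter of the measurement.

Compound 3 `O=C1NC[C@@H](c2c[nH]c3ccccc23)N=C1c1c[nH]c2ccccc12` has not yet been tested in this assay. It differs from compound 2 in a single place: hydrogen in place of bromo on an aromatic carbon. For the measured compounds named here, no pair of measured compounds shows the effect of this particular change, so nothing measured can anchor its size. The bromine is the only heavy atom that departs, and the core is otherwise unchanged, so a step of modest size is expected, most likely toward a higher number, though a result within the scatter cannot be ruled out. The expected step is a 1.7-fold higher number from compound 2 to compound 3 (0.23 log units; within the scatter). Compound 3 is accordingly estimated to give 14 ug/mL, with a likely range from 7 ug/mL to 28 ug/mL.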

Compound 3, concentration for half-maximal effect: 24.1 ug/mL
Compound 3: the middle estimate sits 1.7-fold (0.24 log units) below what was measured; measured number inside the range.
By their numbers in this assay, from the lowest: compound 2; then compounds 1 and 3 (each within the scatter of the next).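

In this assay, hydrogen in place of bromo on an aromatic carbon gives a 2.9-fold higher number from compound 2 to compound 3 (0.46 log units; beyond the scatter), so the group at this place on the six-membered aromatic ring of carbon only does bear on the number. For the compounds shown here, this is the first direct reading of the change, as the two earlier compounds differ in more than one place and gave no step of their own. Of this pair, compound 2, the one that keeps the bromo group, needs less compound for the effect, but nothing at hand shows what lies behind the step.

As far as these compounds go, it remains open whether this step is particular to bromo, or whether chlorine, fluorine, a methoxy group or an amine on the same aromatic carbon would give a number close to that of compound 2 or of compound 3. From the compounds shown here alone, it is also open whether placing a bromo group on the matching aromatic carbon of compound 1 would bring a step of similar size and direction, since one pair cannot show whether the change carries over to another arrangement of the shared core.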